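The source may hold more compounds than are shown below. What is called first, only, known or untested is meant among the compounds shown, and "the series" means these compounds.

Compound 1 `Cc1ccccc1NNC(=O)c1ccc(NS(=O)(=O)c2cnc(O)nc2O)cc1` and compound 2 `Cc1ccccc1NNC(=O)c1ccccc1NS(=O)(=O)c1cnc(O)nc1O` share the same core and were both run in a functional assay on MDA-MB-231 cells (Homo sapiens) for antiproliferative activity, read by MTT assay, with a stated time of 24 h; on this read-out higher numbers stand for weaker inhibition and lower numbers for stronger inhibition. Compound 1 gives only a limit in this assay, > 20000 nM. Compound 2 likewise gives only a limit, > 20000 nM. Where compound 1 stands is therefore fixed solely by the limit of > 20000 nM in this assay, at which 2 of the 2 values shown sit; no step between measured compounds exists, so no size of change can be read from the data so far. Compound 3 `O=C(NNC(=O)c1ccccc1F)c1ccc(NS(=O)(=O)c2cnc(O)nc2O)cc1` is the next compound to be measured. It differs from compound 1 by (2-fluorophenyl)carbonyl in place of 2-methylphenyl on an amine nitrogen. With both measured values sitting at the limit, there is no observed change to anchor the step from compound 1 to compound 3 in this assay, and no movement beyond the scatter is expected. Compound 3 is therefore estimated at 20000 nM, within a range from 8000 nM to 60000 nM, and is most likely to be reported again as a limit. The expected step of a number no higher from compound 1 to compound 3 (the limit leaves the size open) is accordingly flat.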

Compound 3, half-maximal inhibitory concentration: > 20000 nM
Compound 3: only a limit was reported (the forecaster's own chance of this, stated with the estimate: 75%); the middle value lies on the limit itself.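

Among the compounds shown here, compound 1 and compound 3 each give only a limit in this assay, so no step between them can be read: the limit of > 20000 nM in this assay, at which 3 of the 3 values shown sit.

The compounds shown leave open whether any change on the shared core gives a measurable value in this assay.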